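Ring swap on the piperazine nitrogen of compound 3

This account rests on a few compounds, and the source may have more. Where it says the series, first, only, none or still open, it means among the compounds named here.

Compound 3 `CCCc1nc(-c2ccccc2)c(CNCCN2CCN(c3ccc(F)cc3)CC2)o1` gives 7080 nM in an assay on HEK293 cells for inhibition of Voltage-dependent T-type calcium channel subunit alpha-1G (Homo sapiens), read by patch clamp (on this read-out lower numbers stand for stronger inhibition and higher numbers for weaker inhibition), the highest number among the three measured compounds. Compound 1 `CCCc1nc(-c2ccccc2)c(CNCCCN2CCN(c3cccc(C(F)(F)F)c3)CC2)o1` gives 650 nM and compound 2 `CCCc1nc(-c2ccccc2)c(CNCCCN2CCN(c3cccc(F)c3)CC2)o1` gives 3030 nM; compound 3 stands beyond the scatter above both of them. Compound 4 `CCCc1nc(-c2ccccc2)c(CNCCN2CCN(c3ccccc3C)CC2)o1` differs from compound 3 in one place: 2-methylphenyl in place of 4-fluorophenyl on an amine nitrogen in a ring.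

Within the data shown here, only one single-place step has been measured, a 4.7-fold higher number from compound 1 to compound 2 (0.67 log units; beyond the scatter), and it exchanges a substituent on an aromatic carbon rather than replacing the whole aryl ring on the amine nitrogen, so it bears on the present change only loosely. Compound 2 and compound 3 differ in two places at once, so their numbers show only that both lie well above compound 1. Among the measured compounds shown here, no measured step speaks directly to a 2-methylphenyl in this place. Compound 4 is therefore expected to stay close to compound 3, with a 1.4-fold lower number from compound 3 to compound 4 (0.15 log units; within the scatter) lying within the scatter or only modestly beyond it. The estimate for compound 4 is 5000 nM, with a range from 1500 nM to 20000 nM.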

Compound 4, half-maximal inhibitory concentration: 4300 nM
The estimate for compound 4 lay 1.2-fold (0.07 log units) above the measured number; measured number inside the range.
By their numbers in this assay, from the lowest: compound 1; then compounds 2, 4 and 3 (each within the scatter of the next, the first and the last beyond it).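

Putting 2-methylphenyl in place of 4-fluorophenyl on the amine nitrogen in a ring gives a 1.6-fold lower number from compound 3 to compound 4 (0.22 log units; within the scatter) in this assay, so this exchange of one aryl group for another does not separate the two compounds on this read-out. Among these compounds, this is the first measured step at this place, and it differs from the step on the aromatic carbon, a 4.7-fold higher number from compound 1 to compound 2 (0.67 log units; beyond the scatter), which lies beyond the scatter. Nothing shown here accounts for the closeness of these two numbers.

On these data alone, it remains open whether a non-carbocyclic ring such as a pyridine, or a benzyl group, on the same nitrogen would also stay within the scatter of compound 3. Also open, as far as these compounds go, is whether 2-methylphenyl and 4-fluorophenyl would stay as close when carried on the longer chain of compound 1 and compound 2.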